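A few compounds are considered here, and "the series" means these few. Any claim that something is new, unique, unknown or untested is made for them only; others in the source may bear on it.

Working notes on the amidine series. For the measured compounds named here, compound 1 `CCC(NC(=O)c1ccc(C(=N)N)cc1)C(C)(C)C(=O)N1CCC(CC(=O)O)CC1` carries an ethyl group at the chain carbon next to the amide nitrogen; in an in vivo ADME assay on the whole organism (Cavia porcellus) (a lower number here means that the compound disappears faster, a higher number that the compound lasts longer), compound 1 gives 1.3 h, the highest of the three numbers so far. Compound 2 `CC(C)C(NC(=O)c1ccc(C(=N)N)cc1)C(C)(C)C(=O)N1CCC(CC(=O)O)CC1` gives 0.8 h in this assay, and compound 3 `CC(C)(C(=O)N1CCC(CC(=O)O)CC1)C(CCc1ccccc1)NC(=O)c1ccc(C(=N)N)cc1` gives 0.767 h in this assay. Both sit close to compound 1: a 1.6-fold lower number from compound 1 to compound 2 (0.21 log units; within the scatter), and a 1.7-fold lower number from compound 1 to compound 3 (0.23 log units; within the scatter). Between the two larger substituents the numbers are essentially the same, a 1.0-fold lower number from compound 2 to compound 3 (0.02 log units; within the scatter).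

Compound 4 `CC(C)(C(=O)N1CCC(CC(=O)O)CC1)C(NC(=O)c1ccc(C(=N)N)cc1)c1cccc(O)c1` changes the same position: 3-hydroxyphenyl in place of ethyl on a saturated chain carbon bound to an amide-type nitrogen and a saturated chain carbon. All three measured steps bear on this change, since each alters the group on that chain carbon, and each of them stayed within the scatter, with the enlarged substituents tending toward slightly lower numbers. Going by the values given here, an aromatic ring with a hydroxyl has not been tried here, so no step speaks to the hydroxyl itself. For compound 4 the expected step is therefore small, a 1.4-fold lower number from compound 1 to compound 4 (0.16 log units; within the scatter), in the downward direction if any, and not beyond the scatter. Compound 4 is estimated to give 0.9 h in this assay, with a range of 0.4 h to 2 h.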

Compound 4, half-life: 1.08 h
Beside the measured number, compound 4's estimate is 1.2-fold (0.08 log units) below it; the range from low to high includes it.
By their numbers in this assay, from the lowest: compounds 3, 2, 4 and 1 (each within the scatter of the next).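

In this assay, the 3-hydroxyphenyl group extends the range of groups tested on this saturated chain carbon to an aromatic ring carrying a hydroxyl, and every step stays within the scatter: a 1.2-fold lower number from compound 1 to compound 4 (0.08 log units; within the scatter), a 1.4-fold higher number from compound 3 to compound 4 (0.15 log units; within the scatter) and a 1.4-fold higher number from compound 2 to compound 4 (0.13 log units; within the scatter). Replacing ethyl, with its 2 heavy atoms and no hydrogen-bond donor or acceptor, by a group with 7 heavy atoms, one hydrogen-bond donor and one hydrogen-bond acceptor therefore does not separate compound 4 from compounds 1, 2 or 3, and across these four compounds half-life in this assay shows no dependence on the group at this position. No measurement available here accounts for the half-lives of these compounds.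

The role of the hydroxyl remains unresolved, as isolating it would require a direct comparison of 3-hydroxyphenyl with plain phenyl on the same chain carbon. Going by these compounds, it also remains open whether an aminomethyl group or a carboxylic acid at this position would give a step beyond the scatter, or whether these four compounds simply cover too narrow a set of groups to show one.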